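This account rests on a few compounds, and the source may have more. Where it says the series, first, only, none or still open, it means among the compounds named here.

Measured in an assay on Sf9 cells for inhibition of mitogen-activated protein kinase kinase kinase 14 (Homo sapiens), read by ADP-Glo, with a stated time of 60 min; on this read-out lower numbers stand for stronger inhibition and higher numbers for weaker inhibition:
compound 1, `Cc1nn(C(=O)C2CC2)c(N)c1-c1ccc(Cl)c(Cl)c1`: 24300 nM
compound 2, `Cc1nn(C(=O)C2CCCC2)c(N)c1-c1ccc(Cl)c(Cl)c1`: 41000 nM
compound 3, `Cc1nn(C(=O)C2CCCCC2)c(N)c1-c1ccc(Cl)c(Cl)c1`: 3300 nM

Compound 3 stands lowest of the three in this assay: a 7.4-fold lower number from compound 1 to compound 3 (0.87 log units; beyond the scatter) and a 12-fold lower number from compound 2 to compound 3 (1.09 log units; beyond the scatter) are both beyond the scatter, whereas a 1.7-fold higher number from compound 1 to compound 2 (0.23 log units; within the scatter) lies within it.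

Compound 4, `Cc1nn(C(=O)c2ccccc2)c(N)c1-c1ccc(Cl)c(Cl)c1`, has not yet been measured. It differs from compound 3 in one place: phenyl in place of cyclohexyl on a carbonyl carbon. Among the measured compounds shown here, none of the measured steps exchanges a saturated ring for an aromatic one. The steps that were measured all vary the size of the saturated ring on the carbonyl carbon, and they show that this position can move the number by a modest to large amount. Compound 3 already carries a six-membered ring, as compound 4 does, so compound 3 itself is the closest point of reference, and the direction of the change cannot be read from the measured steps. An estimate for compound 4 in this assay is set at 5000 nM, with a range from 1000 nM to 25000 nM. The expected step, a 1.5-fold higher number from compound 3 to compound 4 (0.18 log units; within the scatter), is therefore kept within the scatter, while the range allows for a change in either direction.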

Compound 4, half-maximal inhibitory concentration: 23000 nM
Beside the measured number, compound 4's estimate is 4.6-fold (0.66 log units) below it; measured number inside the range.
By their numbers in this assay, from the lowest: compound 3; then compounds 4, 1 and 2 (each within the scatter of the next).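

In this assay, among the compounds shown here, the earlier steps varied only the size of the saturated ring, and this result shows that size alone does not set the number at this position. Cyclohexyl and phenyl are both six-membered carbon rings with the same heavy-atom count, yet the change from saturated to aromatic gives a 7.0-fold higher number from compound 3 to compound 4 (0.84 log units; beyond the scatter), so the advantage of compound 3 does not extend to every six-membered ring on this carbonyl carbon. Phenyl in place of the smaller saturated rings gives a 1.8-fold lower number from compound 2 to compound 4 (0.25 log units; within the scatter) and a 1.1-fold lower number from compound 1 to compound 4 (0.02 log units; within the scatter), which leaves compound 3 as the only one of the four set apart from the others by more than the scatter.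

Nothing available explains why the aromatic ring and the saturated ring differ here. The compounds shown leave open whether a methoxy group on the phenyl ring would alter the number, and whether a pyridine or piperidine ring, or a cycloheptyl ring, would fall with compound 3 or with compound 4 on this carbonyl carbon.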